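The source may report more compounds than this note shows. Statements on the series, on what has been measured and on what is new or still open speak of the compounds shown alone.

Of the compounds shown here, three sharing one core have been measured in a functional assay on the whole organism (artery, strain albino) with Rattus norvegicus as the target, with a stated time of 180 min, at a dose of 10 mg/kg by the oral route; on this read-out higher numbers stand for more inhibition at the one dose given (going by the name of the read-out) and lower numbers for less inhibition. Compound 1 `CC1=C(C(=O)Nc2ccc(Br)cc2)C(c2ccc(Cl)cc2Cl)N=C(SCc2ccccc2Cl)N1` gives 22.2% in this assay, compound 2 `CC1=C(C(=O)Nc2ccc(Br)cc2)C(c2ccc(Cl)cc2Cl)N=C(SCc2ccc(F)cc2)N1` gives 28.4%, and compound 3 `COc1ccc(C2N=C(SCc3ccccc3Cl)NC(C)=C2C(=O)Nc2ccc(Br)cc2)cc1` gives 11.3%. Compound 3 stands lowest of the three: compound 1 is nearest to it, a gap beyond the scatter, and compound 2 is furthest, also beyond the scatter. Compound 4 `COc1ccc(C2N=C(SCc3ccc(F)cc3)NC(C)=C2C(=O)Nc2ccc(Br)cc2)cc1` has not yet been measured in this assay. It differs from compound 3 in one place: 4-fluorophenyl in place of 2-chlorophenyl on a saturated chain carbon bound to a sulfur. The same exchange has been made once already, between compound 1 and compound 2, where it gave a number 6.2 percentage points higher from compound 1 to compound 2 (within the scatter). The other measured step, a number 10.9 percentage points lower from compound 1 to compound 3 (beyond the scatter), alters a different part of the molecule and does not bear on the present change. On the strength of that single parallel, no step beyond the scatter is expected in this assay for compound 4. Compound 4 is therefore expected to give about 16%, within a range of 5% to 28%, which means an expected step of a number 4.7 percentage points higher from compound 3 to compound 4 (within the scatter).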

Compound 4, a percentage reported as inhibition, in the whole organism at one dose (the size of the read-out at that dose, not a potency): 17%
For compound 4 the middle estimate is 1 percentage points below the measured one, within the range that was stated.
By their numbers in this assay, from the lowest: compounds 3, 4, 1 and 2 (each within the scatter of the next, the first and the last beyond it).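

The exchange of 2-chlorophenyl for 4-fluorophenyl on a saturated chain carbon bound to a sulfur now has a second reading in this assay, a number 5.7 percentage points higher from compound 3 to compound 4 (within the scatter), so on this second core too the step stays inside the scatter. The two readings of this exchange agree closely: the same change on two cores in this assay, a number 6.2 percentage points higher (within the scatter) from compound 1 to compound 2 and a number 5.7 percentage points higher (within the scatter) from compound 3 to compound 4, 0.5 percentage points apart, within the scatter of two such steps. The change to 4-methoxyphenyl in place of 2,4-dichlorophenyl on a saturated ring carbon also repeats, with a number 11.4 percentage points lower from compound 2 to compound 4 (beyond the scatter), and its size holds with 4-fluorobenzyl as with 2-chlorobenzyl: the same change on two cores in this assay, a number 10.9 percentage points lower (beyond the scatter) from compound 1 to compound 3 and a number 11.4 percentage points lower (beyond the scatter) from compound 2 to compound 4, 0.5 percentage points apart, within the scatter of two such steps.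

As far as these compounds go, whether a group of another kind on the sulfur, such as a longer chain ending in an amine or a carboxylic acid, would move the number beyond the scatter stays open. These numbers also come from a single dose and a single time, so they give no potency.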